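From a Dichlorophenyl Amide to a Phenylcyclopropyl Amide

A few compounds are considered here, and "the series" means these few. Any claim that something is new, unique, unknown or untested is made for them only; others in the source may bear on it.

Compound 1 `COc1ccccc1C(=O)Nc1cccc(NC(=O)c2ccc(Cl)c(Cl)c2)c1` and compound 2 `O=C(Nc1cccc(NC(=O)c2ccc(Cl)c(Cl)c2)c1)c1cccc(Cl)c1` share the core of compound 1. In an in vitro functional assay on HEK293-A cells for antagonist activity at metabotropic glutamate receptor 5 (Rattus norvegicus), read by calcium flux (a lower number here means a stronger inhibitor, a higher number a weaker inhibitor), compound 1 gives only a limit, > 30000 nM. In this assay compound 2 likewise gives only a limit, > 30000 nM. The step that the two limits leave unreadable from compound 1 to compound 2 is therefore unreadable, because both values sit at the limit of > 30000 nM in this assay, at which 2 of the 2 values shown sit. Compound 3 `O=C(Nc1cccc(NC(=O)C2CC2c2ccccc2)c1)c1cccc(Cl)c1` differs from compound 2 by 2-phenylcyclopropyl in place of 3,4-dichlorophenyl on a carbonyl carbon. Among the compounds with values here, no measured step bears readably on this change, and compound 2 stands at a limit, so no direction beyond the scatter is expected. Compound 3 is estimated at 30000 nM, ranging from 5000 nM to 100000 nM. The expected step is a number no higher from compound 2 to compound 3 (the limit leaves the size open).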

Compound 3, half-maximal inhibitory concentration: > 30000 nM
Compound 3 ended at the assay's limit (the forecaster's own chance of this, stated with the estimate: 70%); the middle value lies on the limit itself.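

Compound 2 and compound 3 both give only a limit in this assay, so the step between them cannot be read: the limit of > 30000 nM in this assay, at which 3 of the 3 values shown sit. The compounds shown leave open whether any change to the shared core would give a readable value.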